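The compounds below may be only part of what the source reports. "The series", "measured", "known", "first", "only" and "open" are said of these compounds alone.

Working notes on the series, read in a functional assay on HT-29 cells (Homo sapiens) for cytotoxicity, read by sulforhodamine B assay, with a stated time of 96 h (on this read-out lower numbers stand for an effect already at smaller amounts and higher numbers for an effect only at larger amounts of compound), throughout. Compound 1 (`CCCC(=O)CC/C=C/C=C/C#CC#C/C=C/COC(=O)CCl`) gives > 30000 nM as a limit of the assay and not a number. Compound 1 thus stands at the limit of > 30000 nM in this assay, at which 1 of the 2 values shown sits, and no more can be said of it. Among the compounds with values here, compound 2 (`CCCC(=O)CC/C=C/C=C/C#CC#C/C=C/C=O`) gives 22200 nM as the only actual number so far. Within the data shown here, the one measured step, an at least 1.3-fold lower number from compound 1 to compound 2 (0.13 log units; that floor lies within the scatter), is the only evidence at this end of the chain, and it does not separate the two compounds. Compound 3 (`CCCC(=O)CC/C=C/C=C/C#CC#C/C=C/C(=O)O`) follows from compound 2 by one change: hydroxy in place of hydrogen on a carbonyl carbon, or formyl to carboxy. Among the measured compounds shown here, no measured step covers this change, so the expectation starts from compound 2 at 22200 nM and assumes only a small move in this assay, within the scatter and leaning to higher numbers. The expected step is a 1.3-fold higher number from compound 2 to compound 3 (0.10 log units; within the scatter) in this estimate. For compound 3 the estimated value is 28000 nM with an expected range from 11000 nM to 70000 nM, and a limit instead of a number would be no surprise.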

Compound 3, half-maximal effective concentration: > 30000 nM
Compound 3: only a limit was reported (the forecaster's own chance of this, stated with the estimate: 45%); at least 1.0-fold (0.02 log units) between middle value and limit.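

In this assay, within the data shown here, hydroxy in place of hydrogen on a carbonyl carbon, which reads as formyl to carboxy, gives an at least 1.3-fold higher number from compound 2 to compound 3 (0.13 log units; that floor lies within the scatter), so the first change at this carbonyl carbon yields no step that can be told from the scatter. Compound 3 gives > 30000 nM, a limit of the assay and not a number, and the step from compound 1 to compound 3 cannot be read, since both ends of it are limits. With this result, the series shown is defined mostly by one boundary rather than by measured numbers: the limit of > 30000 nM in this assay, at which 2 of the 3 values shown sit.

Among these compounds, compound 2 remains the only compound with an actual number, so the true size of the change from formyl to carboxy stays unknown, and so does any ordering among the three compounds. Also open, on these data alone, is whether a methyl ester or a primary amide on this carbonyl carbon would give a number clear of the limit, or whether the read-out at this position stays at the limit whichever group is placed there.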